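Replacing a terminal vinyl with a diol in an isoflavone ether series

This account rests on a few compounds, and the source may have more. Where it says the series, first, only, none or still open, it means among the compounds named here.

Two compounds share one core and differ only in the chain that hangs from an oxygen on an aromatic ring. Compound 1 `O=c1c(-c2ccc(O)cc2)coc2cc(OCCCCCCBr)ccc12` carries a bromoalkyl chain there, and in an assay on isolated protein (Cricetulus griseus) for inhibition of Monoamine oxidase (Homo sapiens) (a lower number here means a stronger inhibitor, a higher number a weaker inhibitor), compound 1 gives 2000 nM. Compound 2 `C=CCOc1ccc2c(=O)c(-c3ccc(O)cc3)coc2c1` carries an allyloxy group instead, and in this assay compound 2 gives 450 nM. Among the compounds with values here, that change, a 4.4-fold lower number from compound 1 to compound 2 (0.65 log units; beyond the scatter), made compound 2 the lower of the two numbers measured, with compound 1 the only neighbour.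

Compound 3 `O=c1c(-c2ccc(O)cc2)coc2cc(OCC(O)CO)ccc12` is the next step from compound 2: 1,2-dihydroxyethyl in place of vinyl on a saturated chain carbon bound to an oxygen on an aromatic ring. Within the data shown here, no measured pair shows a vinyl being exchanged for a group with hydroxyls, so the one step on record, from compound 1 to compound 2, bears on it only by showing that the tail on this oxygen can shift the number beyond the scatter in either direction. On that footing compound 3 is expected to move by a 2.2-fold higher number from compound 2 to compound 3 (0.35 log units; beyond the scatter) in this assay, toward a somewhat higher number. The estimate for compound 3 is 1000 nM, within a range from 300 nM to 4000 nM.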

Compound 3, half-maximal inhibitory concentration: 1700 nM
Estimate against measurement, compound 3: 1.7-fold (0.23 log units) below; the range from low to high includes it.
By their numbers in this assay, from the lowest: compound 2; then compounds 3 and 1 (each within the scatter of the next).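

In this assay, the change at this position gives a 3.8-fold higher number from compound 2 to compound 3 (0.58 log units; beyond the scatter), the first sign that putting hydroxyl groups on the tail in place of the vinyl gives up the advantage held by the allyloxy compound. Two very different tails, the 2,3-dihydroxypropoxy group and the bromoalkyl chain, also end up level, with a 1.2-fold lower number from compound 1 to compound 3 (0.07 log units; within the scatter), so compound 2 stands alone as the strongest inhibitor of the three, with its steps to both others beyond the scatter. Nothing available explains why these tails give the numbers they do.

The step from compound 2 to compound 3 removes a double bond and adds two hydroxyl groups in one move, so the compounds shown cannot say which of these matters, whereas a saturated propyl tail or a tail with a single hydroxyl would help separate the two. From the compounds shown here alone, how this position would respond to an amine or a carboxylic acid at the end of the chain, or to a longer chain carrying the same pair of hydroxyl groups, also remains open.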